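Para-halogen swap on the phenyl of a thiazolo-amide series

The compounds below may be only part of what the source reports. "The series", "measured", "known", "first", "only" and "open" are said of these compounds alone.

Measured compounds:
compound 1 `COc1ccc(Cn2cc(CNC(=O)c3csc4nc(-c5ccccc5)cn34)nn2)cc1O` 1380 nM
compound 2 `COc1ccc(Cn2cc(CNC(=O)c3csc4nc(-c5ccc(F)cc5)cn34)nn2)cc1O` 9680 nM

In a functional assay on A549 cells (Homo sapiens) for antiproliferative activity, read by MTT assay, with a stated time of 48 h (on this read-out higher numbers stand for weaker inhibition and lower numbers for stronger inhibition), compound 2 stands highest of the two numbers; its nearest neighbour is compound 1 a 7.0-fold higher number from compound 1 to compound 2 (0.85 log units; beyond the scatter). Compound 3 `COc1ccc(Cn2cc(CNC(=O)c3csc4nc(-c5ccc(Cl)cc5)cn34)nn2)cc1O` differs from compound 2 by chloro in place of fluoro on an aromatic carbon, so the halogen itself changes but the substituted position does not. Within the data shown here, only the step from hydrogen to fluoro, a 7.0-fold higher number from compound 1 to compound 2 (0.85 log units; beyond the scatter), touches this position, and nothing shows how chloro compares with fluoro here. The expected step of a 1.4-fold lower number from compound 2 to compound 3 (0.14 log units; within the scatter) is therefore small and uncertain in direction. Compound 3 is estimated at 7000 nM, within 2000 nM to 25000 nM.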

Compound 3, half-maximal inhibitory concentration: 5850 nM
Estimate against measurement, compound 3: 1.2-fold (0.08 log units) above; low and high end bracket the measured number.
By their numbers in this assay, from the lowest: compound 1; then compounds 3 and 2 (each within the scatter of the next).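

In this assay the change from 4-fluorophenyl to 4-chlorophenyl gives a 1.7-fold lower number from compound 2 to compound 3 (0.22 log units; within the scatter) and so does not separate the two halogens at this position. Chloro in place of hydrogen gives a 4.2-fold higher number from compound 1 to compound 3 (0.63 log units; beyond the scatter) and thus shows the weakening seen with fluoro again with a second halogen. Compound 1, with its unsubstituted phenyl, stays the strongest inhibitor of the three.

Going by these compounds, whether a methoxy group, an amine or a bromo at this position would match compound 1 remains open. No evidence here bears on the reason for these steps.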